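The compounds below may be only part of what the source reports. "The series", "measured", "known", "first", "only" and "open" are said of these compounds alone.

Measured compounds:
compound 1, `CC#CCn1c(N2CCC[C@@H](N)C2)nc2c1c(=O)n(Cc1ccc(Br)cc1C(=O)OCC)c(=O)n2C` — > 100000 nM
compound 2, `CC#CCn1c(N2CCC[C@@H](N)C2)nc2c1c(=O)n(Cc1cc(OC)ccc1C(=O)O)c(=O)n2C` — > 100000 nM
compound 3, `CC#CCn1c(N2CCC[C@@H](N)C2)nc2c1c(=O)n(Cc1c(OC)cccc1C(=O)O)c(=O)n2C` — > 100000 nM

The account follows the step from compound 1 to compound 4, `CC#CCn1c(N2CCC[C@@H](N)C2)nc2c1c(=O)n(Cc1ccc(F)cc1C(=O)O)c(=O)n2C`, which has not yet been measured. In an ADME assay on isolated protein for inhibition of Dipeptidyl peptidase 9 (Homo sapiens), with stated times of 15 min, 60 s and 20 min (a higher number here means a weaker inhibitor, a lower number a stronger inhibitor), compound 1 gives > 100000 nM, which is a limit of the assay and not a number. In this assay compound 2 likewise gives > 100000 nM, a limit. In this assay compound 3 gives > 100000 nM, also a limit. Compound 1 therefore stands at the limit, as do the two others, and none of the three is placed above or below another.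

The change to compound 4 is 2-carboxy-4-fluorophenyl in place of 4-bromo-2-(ethoxycarbonyl)phenyl on a saturated chain carbon bound to an aromatic nitrogen. The measured steps that touch the same position are a step that the two limits leave unreadable from compound 1 to compound 2, a step that the two limits leave unreadable from compound 1 to compound 3 and a step that the two limits leave unreadable from compound 2 to compound 3; none of them has a readable size, because of the limit of > 100000 nM in this assay, at which 3 of the 3 values shown sit. Among the measured compounds shown here, no step that replaces this group has yet moved a compound off the limit, so no step beyond the scatter in this assay is expected for compound 4 in either direction, and a further limit is the most likely outcome.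

Compound 4 is accordingly estimated at 100000 nM in this assay, with a range from 30000 nM to 300000 nM. The expected step is a number no higher from compound 1 to compound 4 (the limit leaves the size open).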

Compound 4, half-maximal inhibitory concentration: > 100000 nM
Compound 4: no number, only a limit (the forecaster's own chance of this, stated with the estimate: 85%); the middle value sits exactly at the limit.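

In this assay compound 4 stands with compound 1, compound 2 and compound 3, so no step among these four compounds can be read, their values being limits of the assay and not numbers: the limit of > 100000 nM in this assay, at which 4 of the 4 values shown sit. The compounds shown leave open how far each lies from that limit and whether any group at this place gives a measurable value.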